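The compounds below may be only part of what the source reports. "The series", "measured", "known", "first", "only" and "open" are said of these compounds alone.

In a functional assay on MCF7 cells (Homo sapiens) for inhibition, read by colorimetric assay and MTT assay, with a stated time of 72 h (a higher number here means a weaker inhibitor, a lower number a stronger inhibitor), compound 2 `Cc1ccc(C(=O)NNC(=S)Nc2csc(-c3ccc(C)cc3)c2)cc1` gives 29000 nM. This lies within the scatter of compound 3 `COc1cc(C(=O)NNC(=S)Nc2csc(-c3ccc(C)cc3)c2)cc(OC)c1OC`, at 31000 nM, and of compound 1 `COc1ccc(-c2cc(NC(=S)NNC(=O)c3ccc(C)cc3)cs2)cc1`, at 40000 nM, so the numbers do not separate the three. Compound 4 `COc1ccc(C(=O)NNC(=S)Nc2csc(-c3ccc(C)cc3)c2)cc1` differs from compound 2 by one exchange, methoxy in place of methyl on an aromatic carbon, para to a large group: methoxy in place of methyl on an aromatic carbon. Among the compounds with values here, the only measured step of this kind runs the opposite way, methyl in place of methoxy, at another place on the molecule, and it is a 1.4-fold lower number from compound 1 to compound 2 (0.14 log units; within the scatter). On that single step, no change beyond the scatter is expected in this assay. The expected step is a 1.1-fold higher number from compound 2 to compound 4 (0.06 log units; within the scatter). For compound 4 the estimate is 33000 nM, with an expected range of 18000 nM to 60000 nM.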

Compound 4, half-maximal inhibitory concentration: 5000 nM
Compound 4: the middle estimate sits 6.6-fold (0.82 log units) above what was measured; measured number below the stated range.
By their numbers in this assay, from the lowest: compound 4; then compounds 2, 3 and 1 (each within the scatter of the next).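

In this assay, the change from 4-methylphenyl to 4-methoxyphenyl at this position gives a 5.8-fold lower number from compound 2 to compound 4 (0.76 log units; beyond the scatter), beyond the scatter, while the same two groups exchanged at the other place on the molecule gave a 1.4-fold lower number from compound 1 to compound 2 (0.14 log units; within the scatter), within the scatter. Across these compounds, the outcome of this exchange therefore depends on where it is made. Nothing available explains this difference. On these data alone, it remains open whether an ethoxy group, a hydroxyl or an amine at this position would give a similar number. The gain also rests on a single pair of compounds.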